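This account rests on a few compounds, and the source may have more. Where it says the series, first, only, none or still open, it means among the compounds named here.

Measured compounds in the series:

Compound 1 `CCNC(=O)N1CCN(C(=S)SCc2cn(Cc3ccc(C)cc3)nn2)CC1` gives > 128000 nM in a functional assay on EC9706 cells (Homo sapiens) for cytotoxicity, read by MTT assay, with a stated time of 72 h (a lower number here means a stronger inhibitor, a higher number a weaker inhibitor), which is a limit of the assay and not a number.
Compound 2 `Cc1ccc(Cn2cc(CSC(=S)N3CCN(C(=O)NC(C)C)CC3)nn2)cc1` gives > 128000 nM in this assay, again a limit.
Compound 3 `CCNC(=O)N1CCN(C(=S)SCc2cn(Cc3ccc(OC)cc3)nn2)CC1` gives > 128000 nM in this assay, likewise a limit.

All three values sit at the same point, namely (the limit of > 128000 nM in this assay, at which 3 of the 3 values shown sit). The change from compound 1 to compound 2 is methyl in place of hydrogen on a saturated chain carbon bound to an amide-type nitrogen and a saturated chain carbon, and the step it made reads a step that the two limits leave unreadable from compound 1 to compound 2. The two cores differ as methoxy in place of methyl on an aromatic carbon, with the step that the two limits leave unreadable from compound 1 to compound 3. Neither step can be sized, since both ends are limits.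

Compound 4 `COc1ccc(Cn2cc(CSC(=S)N3CCN(C(=O)NC(C)C)CC3)nn2)cc1` is not yet measured. It differs from compound 3 by methyl in place of hydrogen on a saturated chain carbon bound to an amide-type nitrogen and a saturated chain carbon, at a place described in exactly the same words as for the change from compound 1 to compound 2, so this is the same change on the other core. Given that compound 1 and compound 2 both sit at the limit of > 128000 nM in this assay, at which 3 of the 3 values shown sit, the step from compound 3 to compound 4 is expected to be about a step that the limit leaves unreadable from compound 3 to compound 4, with no evidence that the methyl moves the read-out off the limit. For compound 4 the estimate in this assay is therefore 250000 nM, within a range from 120000 nM to 600000 nM, and most likely the assay again reports only a limit.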

Compound 4, half-maximal inhibitory concentration: > 128000 nM
Compound 4 was reported as a limit; the forecaster's own chance of this, stated with the estimate: 85%; the middle value is on the limit's open side.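

In this assay compound 4 gives > 128000 nM as a limit of the assay and not a number, so no step can be read from compound 3 or compound 2 to compound 4. The compounds shown leave open whether ethyl to isopropyl or methoxy in place of methyl changes the read-out at all, as every value sits at one point: the limit of > 128000 nM in this assay, at which 4 of the 4 values shown sit.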